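The source may hold more compounds than are shown below. What is called first, only, known or untested is meant among the compounds shown, and "the series" means these compounds.

Working notes on the series. Compound 1 `c1ccc(COc2ccccc2Nc2ncnc3cc4c(cc23)OCCOCCO4)cc1` is the weaker of the two measured compounds in a functional assay on SH-SY5Y cells (Homo sapiens) for antiproliferative activity, read by MTT assay, with a stated time of 72 h (on this read-out higher numbers stand for weaker inhibition and lower numbers for stronger inhibition), where compound 1 gives 93700 nM; this is the highest number among the two values at hand. Among the compounds with values here, the other measured compound, compound 2 `FC(F)(F)c1ccc(COc2cccc(Nc3ncnc4cc5c(cc34)OCCOCCOCCOCCO5)c2)cc1`, differs from compound 1 in more than one place, so no single-change step connects them; in this assay compound 2 gives 8560 nM, a lower number that lies beyond the scatter.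

Compound 3 `O=[N+]([O-])c1ccc(COc2ccccc2Nc2ncnc3cc4c(cc23)OCCOCCO4)cc1` is not yet measured. It differs from compound 1 by one change: nitro in place of hydrogen on an aromatic carbon, para to a large group. Within the data shown here, no measured pair carries this same change, so there is no recorded step to lean on.

Among the measured compounds shown here, with no comparable step known, the expected step from compound 1 to compound 3 is a 1.6-fold lower number from compound 1 to compound 3 (0.19 log units; within the scatter), a small shift estimated to stay close to the scatter. Compound 3 is therefore expected to give about 60000 nM in this assay, with a plausible range from 25000 nM to 200000 nM.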

Compound 3, half-maximal inhibitory concentration: > 100000 nM
Compound 3: no number, only a limit (the forecaster's own chance of this, stated with the estimate: 15%); middle value at least 1.6-fold (0.22 log units) away from the limit.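

In this assay compound 3 gives > 100000 nM, which is a limit of the assay and not a number. Going by these compounds, the step reads an at least 1.0-fold higher number from compound 1 to compound 3 (0.02 log units; that floor lies within the scatter), so it fixes only a floor: nitro in place of hydrogen on this aromatic carbon, para to a large group, does not give a lower number than compound 1, and the true size of any rise stays unknown. What can be said of compound 3 rests on a limit alone: the limit of > 100000 nM in this assay, at which 1 of the 3 values shown sits.

The compounds shown leave open whether an amine or a carboxylic acid on this aromatic carbon would give a lower number than compound 1. Within the data shown here, the gap between compound 1 and compound 2 also stays unresolved: no single-change step joins them, and none of their differences can be weighed alone.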